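The source may report more compounds than this note shows. Statements on the series, on what has been measured and on what is new or still open speak of the compounds shown alone.

Measured compounds in a functional assay on cells (T-cell, Mus musculus) for inhibition; a higher number here means a weaker inhibitor, a lower number a stronger inhibitor:
compound 1, `COc1cc(CCC(=O)Nc2ccc3c(c2)COC3=O)cc(OC)c1OC`: 7740 nM
compound 2, `Cc1cccc(NC(=O)Nc2ccc3c(c2)COC3=O)c1`: 2260 nM

Within the data shown here, both compounds share the same core; they differ from each other in more than one place, so no single step connects them and their two values stand alone. Of the two numbers, compound 2 has the lower one, and compound 1 sits a clear distance above it, beyond the usual scatter of this assay. Compound 2 is therefore the stronger inhibitor of the pair on the numbers shown so far.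

Compound 3, `CCCNC(=O)Nc1ccc2c(c1)COC2=O`, has not yet been measured in this assay. It differs from compound 2 in one place: propyl in place of 3-methylphenyl on an amide-type nitrogen. The aromatic ring on the amide-type nitrogen is given up for a short chain. Among the measured compounds shown here, no measured pair shows a change of this kind, so the step has to be estimated without a precedent. The expectation is a move to a weaker inhibitor, with a 3.5-fold higher number from compound 2 to compound 3 (0.55 log units; beyond the scatter) estimated to lie beyond the scatter rather than within it. For compound 3 the estimate in this assay is 8000 nM, with a range from 2500 nM to 30000 nM.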

Compound 3, half-maximal inhibitory concentration: 58100 nM
For compound 3 the middle estimate is 7.3-fold (0.86 log units) below the measured one; the whole stated range lies below it.
By their numbers in this assay, from the lowest: compound 2; then compound 1; then compound 3.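

In this assay, among these compounds, the group on the amide-type nitrogen is the first place where a single change can be read, and propyl in place of 3-methylphenyl gives a 26-fold higher number from compound 2 to compound 3 (1.41 log units; beyond the scatter) with compound 3 at 58100 nM on this shared core. The position is therefore far from indifferent to its substituent, even though the change involves only carbon: a six-membered aromatic ring leaves, the group drops from 7 heavy atoms to 3, and no hydrogen-bond donor, acceptor or charge enters or leaves. Nothing available explains the size of this step.

This single step cannot separate the loss of the aromatic ring from the loss of heavy atoms, and a cyclohexyl ring or a longer chain such as heptyl on the same nitrogen would address that question. On these data alone, how much of the value of compound 2 depends on the methyl group also remains open, as a plain phenyl or a 3-chlorophenyl group at this position would be needed to show it.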